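A few compounds are considered here, and "the series" means these few. Any claim that something is new, unique, unknown or untested is made for them only; others in the source may bear on it.

Compound 1 `OC[C@H]1O[C@@H](n2cnc3c(NCc4ccccc4Cl)ncnc32)[C@H](O)[C@@H]1O` carries a 2-chlorobenzyl group on the shared core. Going by the values given here, in a functional assay on HL-60 cells (Homo sapiens) for antiproliferative activity, with a stated time of 72 h (a higher number here means a weaker inhibitor, a lower number a stronger inhibitor), compound 1 gives 1600 nM, the lowest of the three numbers measured so far. Compound 2 `Cc1cccc(CNc2ncnc3c2ncn3[C@@H]2O[C@H](CO)[C@@H](O)[C@H]2O)c1` gives 6400 nM in this assay, and compound 3 `COc1cc(CNc2ncnc3c2ncn3[C@@H]2O[C@H](CO)[C@@H](O)[C@H]2O)cc(OC)c1` gives 20200 nM. Both of these are replacements of the 2-chlorophenyl group of compound 1, and both weakened inhibition: a 4.0-fold higher number from compound 1 to compound 2 (0.60 log units; beyond the scatter) and a 13-fold higher number from compound 1 to compound 3 (1.10 log units; beyond the scatter). Between the two replacements, a 3.2-fold higher number from compound 2 to compound 3 (0.50 log units; beyond the scatter).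

Compound 4 `Cc1ccc(O)c(CNc2ncnc3c2ncn3[C@@H]2O[C@H](CO)[C@@H](O)[C@H]2O)c1` is the next variation at the same place. Relative to compound 1 it differs in a single group: 2-hydroxy-5-methylphenyl in place of 2-chlorophenyl on a saturated chain carbon bound to a nitrogen on an aromatic ring. The two measured steps that bear on it, those from compound 1 to compound 2 and from compound 1 to compound 3, are modest and large, and both point the same way, toward a higher number in this assay whenever the 2-chlorophenyl group is exchanged. The entering group differs from the two exchanged ones in carrying a hydrogen-bond donor and acceptor, for which no measured comparison exists, so the size of the expected step is uncertain. A step in the same direction is expected, a 3.8-fold higher number from compound 1 to compound 4 (0.57 log units; beyond the scatter), of modest size. Compound 4 is therefore estimated to give 6000 nM in this assay, within a range from 2500 nM to 15000 nM.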

Compound 4, half-maximal inhibitory concentration: 15000 nM
Estimate against measurement, compound 4: 2.5-fold (0.40 log units) below; measured number inside the range.
By their numbers in this assay, from the lowest: compound 1; then compound 2; then compounds 4 and 3 (each within the scatter of the next).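

Going by these compounds alone, the result shows that a hydroxy group on this ring can itself weaken inhibition in this assay: the one-place change gives a 2.3-fold higher number from compound 2 to compound 4 (0.37 log units; beyond the scatter), the first step here that adds a group to the ring of compound 2 rather than exchanging the whole aryl group. It also extends the earlier trend. All three groups that replace 2-chlorophenyl raise the number, none goes against it, and the new exchange gives a 9.4-fold higher number from compound 1 to compound 4 (0.97 log units; beyond the scatter). The 2-hydroxy-5-methylphenyl and 3,5-dimethoxyphenyl groups differ in their counted hydrogen-bond donors and yet remain within the scatter of each other, with a 1.3-fold lower number from compound 3 to compound 4 (0.13 log units; within the scatter), so the higher numbers at this position are not confined to one kind of replacement.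

No available evidence accounts for the size or direction of these steps. Still open, on these data alone, is whether the chlorine of compound 1 matters in its own right, which a 2-fluorophenyl or 2-methylphenyl group at this place would test, and whether an amine or a methoxy group in place of the hydroxy of compound 4 would give a similar number.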